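The source may hold more compounds than are shown below. What is called first, only, known or untested is meant among the compounds shown, and "the series" means these compounds.

Four compounds built around a biphenyl-type core were compared in an in vitro assay on BTI-TN-5B1-4 cells for inhibition of sterol O-acyltransferase 2 (Homo sapiens), tested at 50 uM; on this read-out higher numbers stand for more inhibition at the one concentration tested (going by the name of the read-out) and lower numbers for less inhibition. Compound 1 `CCCCCCCC(=O)Nc1ccc(-c2ccccc2)cc1` carries an amide with a straight chain; in this assay compound 1 gives 11%. Compound 2 `CCCCCCCCC(=O)Nc1ccc(-c2ccccc2)cc1` differs from it by methyl in place of hydrogen on a saturated chain carbon, seven bonds along the chain from a carbonyl carbon. In this assay compound 2 gives 20%, so that a number 9 percentage points higher from compound 1 to compound 2 (within the scatter), a step that stays inside what repeated measurements of this kind usually scatter over, and therefore does not by itself show that the longer chain does anything.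

Compound 3 `CCCCCCCCNc1ccccc1-c1ccccc1` replaces the amide with a plain amine attached to the aromatic ring and moves the second ring to a different position; how its core differs from the core of compound 1 is not broken down here. In this assay compound 3 gives -4%, the lowest of the three numbers, and its distances to compound 1 and to compound 2 both lie beyond the usual scatter.

Compound 4 `CCCCCCCCCNc1ccccc1-c1ccccc1` has not been measured yet. It differs from compound 3 by methyl in place of hydrogen on a saturated chain carbon, eight bonds along the chain from a nitrogen on an aromatic ring. Among the compounds with values here, this is the same kind of change as the one from compound 1 to compound 2, though the surroundings differ: there the methyl entered seven bonds along the chain from a carbonyl carbon, here eight bonds along the chain from a nitrogen on an aromatic ring. Within the data shown here, the only guide is that single earlier step, a number 9 percentage points higher from compound 1 to compound 2 (within the scatter), which was within the scatter; on that basis the step of a number 6 percentage points higher from compound 3 to compound 4 (within the scatter) is expected to be small as well. Compound 4 is therefore estimated to give 2%, somewhere between -10% and 14%.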

Compound 4, a percentage reported as inhibition, at one concentration (the size of the read-out at that concentration, not a potency): -1%
Compound 4: the middle estimate sits 3 percentage points above what was measured; low and high end bracket the measured number.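

Adding the methyl on the core of compound 3 gives a number 3 percentage points higher from compound 3 to compound 4 (within the scatter) in this assay and so, like the same change on the core of compound 1, shows no effect that stands clear of repeated measurement. Within the data shown here, the change therefore looks alike on the two cores, but this is only agreement between two small steps: a step inside the scatter cannot be told apart from no step at all, so it does not show that the methyl does the same thing on both cores, and two pairs cannot speak for any other core. Side by side, the two steps do not differ by more than such pairs usually scatter: the same change on two cores in this assay, a number 9 percentage points higher (within the scatter) from compound 1 to compound 2 and a number 3 percentage points higher (within the scatter) from compound 3 to compound 4, 6 percentage points apart, within the scatter of two such steps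

The compounds shown leave open whether a much longer chain, or a chain ending in an amine or a carboxylic acid, would move the number clear of the scatter on either core. They also leave open what the amide contributes on its own, as compound 1 and compound 3 differ in more than one place and the gap between them cannot be pinned on any single part.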